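Methyl for nitro on a pyridazine-linked aryl ring in mice

This account rests on a few compounds, and the source may have more. Where it says the series, first, only, none or still open, it means among the compounds named here.

Measured so far:
compound 1 `OC1CCN(c2ccc(-c3ccccc3F)nn2)CC1` — 115 mg/kg
compound 2 `O=[N+]([O-])c1ccccc1-c1ccc(N2CCC(O)CC2)nn1` — 27 mg/kg

Of the compounds shown here, two sharing a common core have been tested in a functional assay on the whole organism with Mus musculus as the target, in the maximal electroshock model; on this read-out lower numbers stand for an effect already at smaller amounts and higher numbers for an effect only at larger amounts of compound. Compound 1 gives 115 mg/kg and compound 2 gives 27 mg/kg. Within the data shown here, compound 2 thus stands at the lower of the two numbers, with compound 1 as its only neighbour at a 4.3-fold lower number from compound 1 to compound 2 (0.63 log units; beyond the scatter), a step that was beyond the scatter.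

Compound 3 `Cc1ccccc1-c1ccc(N2CCC(O)CC2)nn1` is the next member. It differs from compound 2 by methyl in place of nitro on an aromatic carbon. Among the measured compounds shown here, the only step that bears on this change is the one from compound 1 to compound 2, a 4.3-fold lower number from compound 1 to compound 2 (0.63 log units; beyond the scatter), which shows that what sits on this aromatic carbon matters to this assay. Methyl is a different group from either fluoro or nitro, so the step cannot be read off directly; the expectation is that compound 3 falls between the two measured values, closer to compound 2. The estimated step is a 2.2-fold higher number from compound 2 to compound 3 (0.35 log units; beyond the scatter), meaning compound 3 is expected at about 60 mg/kg, within a range from 25 mg/kg to 140 mg/kg.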

Compound 3, dose for half-maximal effect: 30 mg/kg
Beside the measured number, compound 3's estimate is 2.0-fold (0.30 log units) above it; the range from low to high includes it.
By their numbers in this assay, from the lowest: compounds 2 and 3 (each within the scatter of the next); then compound 1.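

In this assay the change to methyl in place of nitro on this aromatic carbon, ortho to a large group, gives a 1.1-fold higher number from compound 2 to compound 3 (0.05 log units; within the scatter) and so leaves the read-out within the scatter, although nitro brings nitrogen, oxygen and hydrogen-bond acceptors and methyl brings none of these. Methyl in place of fluoro gives a 3.8-fold lower number from compound 1 to compound 3 (0.58 log units; beyond the scatter) and beyond the scatter, so the lower number seen with compound 2 is not tied to nitro alone, and fluoro is the group that stands apart among the three. No supporting data are available to explain why fluoro differs from methyl and nitro at this position.

The compounds shown leave open whether fluoro is an exception at this place or whether groups such as chloro, methoxy or an amine would fall with methyl and nitro. They also leave open how compounds with a plain hydrogen on this carbon, or with methyl moved to another carbon of the same ring, would compare with compound 3.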